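Series notes: benzyl for cyclohexyl on a ring nitrogen

This account rests on a few compounds, and the source may have more. Where it says the series, first, only, none or still open, it means among the compounds named here.

Two compounds carry measurements in a functional assay on 786-0 cells (Homo sapiens) for inhibition, read by sulforhodamine B assay, with a stated time of 48 h, tested at 10 uM; on this read-out higher numbers stand for more inhibition at the one concentration tested (going by the name of the read-out) and lower numbers for less inhibition. Compound 1 `c1csc(-c2cn3ccnc3c(-c3ccc4ncn(C5CCCCC5)c4c3)n2)c1` gives 4.1% in this assay. Compound 2 `c1cn2cc(-c3ccc4c(c3)ncn4C3CCCCC3)nc(-c3ccc4ncn(C5CCCCC5)c4c3)c2n1` gives 25.8% in this assay, the higher of the two numbers; its gap to compound 1 lies beyond the scatter, so the inhibition in this assay is higher for compound 2 than for compound 1. Among the measured compounds shown here, the two differ in more than one place, so no single step is counted between them.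

Compound 3 `c1ccc(Cn2cnc3ccc(-c4nc(-c5ccc6c(c5)ncn6C5CCCCC5)cn5ccnc45)cc32)cc1` is not yet measured. Against compound 2 it differs as follows: benzyl in place of cyclohexyl on an aromatic nitrogen. For the measured compounds named here, no measured pair shows this exchange, so its effect is open and the measured numbers give no lead on direction. The expectation is a step in this assay of small size, in either direction, or none beyond the scatter. Compound 3 is estimated at 22% in this assay, within 5% to 45%. The step of a number 3.8 percentage points lower from compound 2 to compound 3 (within the scatter) is expected to stay within the scatter.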

Compound 3, a percentage reported as inhibition, at one concentration (the size of the read-out at that concentration, not a potency): -19.4%
Compound 3: middle estimate off by 41.4 percentage points, on the high side; measured number outside the range, below it.
By their numbers in this assay, from the lowest: compound 3; then compound 1; then compound 2.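

In this assay, among the compounds shown here, the change from cyclohexyl to benzyl on this aromatic nitrogen gives a number 45.2 percentage points lower from compound 2 to compound 3 (beyond the scatter), so this position, where the earlier compounds show only cyclohexyl, responds strongly to the group it carries. Compound 3 gives -19.4%, a number below zero, so with this single exchange no inhibition remains to be read at the one concentration tested, even though the other cyclohexyl-bearing nitrogen of compound 3 stays as in compound 2. Nothing at hand bears on what lies behind this step.

For the compounds shown here, the single exchange leaves open whether the loss follows the aromatic ring of benzyl or its methylene link, and a cyclohexylmethyl or phenyl group on the same nitrogen would separate these two parts of the change. Also open, going by these compounds, is whether the other cyclohexyl position of compound 2 answers the same exchange in the same way, and whether a group of another kind at this nitrogen, such as a piperidine amine or a short alkyl chain, keeps or raises the inhibition seen for compound 2.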